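The compounds below may be only part of what the source reports. "The series", "measured", "known", "first", "only" and "open" are said of these compounds alone.

Compound 1 `O=C(COc1ccc(C(=O)/C=C/c2cccc(Cl)c2)cc1)N[C@H]1CCOC1=O` and compound 2 `O=C(COc1ccc(C(=O)/C=C/c2ccc(Cl)cc2Cl)cc1)N[C@H]1CCOC1=O` share one core and differ only in the chlorine pattern of the ring at the far end of the double-bonded chain. In a functional assay on PC-3 cells (Homo sapiens) for antiproliferative activity, read by MTT assay, with a stated time of 72 h (on this read-out higher numbers stand for weaker inhibition and lower numbers for stronger inhibition), compound 1 gives 4990 nM, and in this assay compound 2 gives 8040 nM. The swap of 2,4-dichlorophenyl in place of 3-chlorophenyl on the double-bonded chain carbon brings a 1.6-fold higher number from compound 1 to compound 2 (0.21 log units; within the scatter), so the two numbers cannot be told apart with confidence; compound 2 simply stands at the end with the somewhat higher number of the two.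

Compound 3 `O=C(COc1ccc(C(=O)/C=C/c2ccccc2Cl)cc1)N[C@H]1CCOC1=O` is reached from compound 2 by hydrogen in place of chloro on an aromatic carbon. Going by the values given here, the only measured step that bears on this, moving chlorines around the same ring, was a 1.6-fold higher number from compound 1 to compound 2 (0.21 log units; within the scatter), which gives no sign that this ring tolerates chlorine changes with any strong effect. An expected step of a 1.3-fold lower number from compound 2 to compound 3 (0.13 log units; within the scatter) therefore seems reasonable, with no direction beyond the scatter. Compound 3 is estimated at 6000 nM, within a range from 2500 nM to 15000 nM.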

Compound 3, half-maximal inhibitory concentration: 4610 nM
Estimate against measurement, compound 3: 1.3-fold (0.11 log units) above, and the stated range covers the measured number.
By their numbers in this assay, from the lowest: compounds 3, 1 and 2 (each within the scatter of the next).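

Taking away the chloro group that sits para to a large group, which turns 2,4-dichlorophenyl into 2-chlorophenyl, gives a 1.7-fold lower number from compound 2 to compound 3 (0.24 log units; within the scatter) in this assay, so with chloro or with hydrogen at this ring position the two compounds cannot be told apart. Shifting the single chlorine, with 2-chlorophenyl in place of 3-chlorophenyl, gives a 1.1-fold lower number from compound 1 to compound 3 (0.03 log units; within the scatter), and this step too cannot be read as a real difference, so neither adding a second chlorine nor moving the only one has yet shown a clear effect in these compounds. Nothing available here offers an explanation for how closely these three numbers sit together (no supporting data bear on it).

As far as these compounds go, all three compounds still carry at least one chlorine on this ring, so it remains open whether a ring with no chlorine at all, or one bearing a methoxy group, an amine or a carboxylic acid, would move the number beyond the scatter. The shared core is also the same throughout, which leaves open how much changes elsewhere in the molecule would matter.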